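Moving from compound 2 to compound 4 in the cytotoxicity assay

The source may hold more compounds than are shown below. What is called first, only, known or untested is meant among the compounds shown, and "the series" means these compounds.

The measured compounds:
Compound 1, `O=C(CSc1snnc1-c1ccc(F)cc1F)Nc1ccccc1F`: 148000 nM in an ADME assay on MT4 cells (Homo sapiens) for cytotoxicity; a lower number here means that less compound is tolerated, a higher number that more compound is tolerated
Compound 2, `Cc1ccc(NC(=O)CSc2snnc2-c2ccc(F)cc2F)c(Br)c1`: compound 2 gives > 273000 nM, a limit of this assay
Compound 3, `Cc1ccc(NC(=O)CSc2snnc2-c2ccccc2)c(Br)c1`: compound 3 gives > 297000 nM, likewise a limit

Compound 2 therefore stands only at a limit, (the limit of > 273000 nM in this assay, at which 1 of the 3 values shown sits), not at a number, and compound 3 stands at the other limit, (the limit of > 297000 nM in this assay, at which 1 of the 3 values shown sits). Compound 4, `O=C(CSc1snnc1-c1ccc(F)cc1F)Nc1ccccc1Cl`, is not yet measured. It differs from compound 2 in one place: 2-chlorophenyl in place of 2-bromo-4-methylphenyl on an amide-type nitrogen.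

Two measured steps exist. an at least 1.8-fold higher number from compound 1 to compound 2 (0.26 log units; that floor lies within the scatter), and a step that the two limits leave unreadable from compound 2 to compound 3. The first is the nearer relative of the present change, since compound 1 also carries a small halogenated phenyl on the amide-type nitrogen, and it points toward a somewhat lower number when the 2-bromo-4-methylphenyl is replaced. The second step gives no readable size.

Compound 4 is therefore expected to fall somewhat below compound 2, an estimated at least 1.5-fold lower number from compound 2 to compound 4 (0.18 log units; that floor lies within the scatter), with the caveat that compound 2 is only a limit. The estimate for compound 4 is 180000 nM, within 90000 nM to 350000 nM.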

Compound 4, half-maximal cytotoxic concentration: 178000 nM
For compound 4 the middle estimate is 1.0-fold (0.00 log units) above the measured one; measured number inside the range.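

In this assay, chloro in place of fluoro on an aromatic carbon gives a 1.2-fold higher number from compound 1 to compound 4 (0.08 log units; within the scatter), so the two halogens cannot be told apart at this place. Replacing the larger group on the amide-type nitrogen, 2-chlorophenyl in place of 2-bromo-4-methylphenyl gives an at least 1.5-fold lower number from compound 2 to compound 4 (0.18 log units; that floor lies within the scatter), and this floor alone does not establish a real drop. Compound 2 stands only at a limit, so the full size of that step stays unknown: the limit of > 273000 nM in this assay, at which 1 of the 4 values shown sits.

On these data alone, whether the bromo or the methyl of the 2-bromo-4-methylphenyl goes with that limit remains open. Also open, as far as these compounds go, is how a phenyl on the amide-type nitrogen carrying a different kind of group, such as an amine or a carboxylic acid, would read in this assay.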